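The compounds below may be only part of what the source reports. "The series", "measured", "known", "first", "only" and "open" are said of these compounds alone.

Compound 1, `ClCc1ccc(Cn2cnc3c(Cl)ncnc32)cc1`, is the starting point of this small set. In a functional assay on UACC-257 cells (Homo sapiens) for cytotoxicity, read by sulforhodamine B assay, with a stated time of 48 h (a higher number here means that more compound is tolerated, a lower number that less compound is tolerated), compound 1 gives 97700 nM. Compound 2, `Nc1nc(Cl)c2ncn(Cc3ccc(CCl)cc3)c2n1`, carries amino in place of hydrogen on an aromatic carbon. In this assay compound 2 reaches only a limit of the assay, > 100000 nM. The change gave an at least 1.0-fold higher number from compound 1 to compound 2 (0.01 log units; that floor lies within the scatter), resting on (the limit of > 100000 nM in this assay, at which 1 of the 3 values shown sits). Compound 3, `ClCc1ccccc1Cn1cnc2c(Cl)ncnc21`, has the same atoms as compound 1 joined differently; the difference between the two cores is not broken down here. In this assay compound 3 gives 66100 nM. Compound 4, `Nc1nc(Cl)c2ncn(Cc3ccccc3CCl)c2n1`, has not yet been measured; it carries amino in place of hydrogen on an aromatic carbon, the same change seen before. The step in this assay from compound 3 to compound 4 is expected to be a 1.2-fold higher number from compound 3 to compound 4 (0.08 log units; within the scatter) because an at least 1.0-fold higher number from compound 1 to compound 2 (0.01 log units; that floor lies within the scatter) showed little movement. Compound 4 is therefore estimated at about 80000 nM, likely between 40000 nM and 160000 nM.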

Compound 4, concentration lethal to 50% of the cells: > 100000 nM
Compound 4: only a limit was reported; the forecaster's own chance of this, stated with the estimate: 35%; at least 1.2-fold (0.09 log units) between middle value and limit.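

In this assay, placing an amino group on the core of compound 3 gives an at least 1.5-fold higher number from compound 3 to compound 4 (0.17 log units; that floor lies within the scatter). Set beside the earlier case, the change on the two cores compares only this far: the same change on two cores in this assay, an at least 1.0-fold higher number (0.01 log units; that floor lies within the scatter) from compound 1 to compound 2 and an at least 1.5-fold higher number (0.17 log units; that floor lies within the scatter) from compound 3 to compound 4; the limit leaves it open whether they differ. Both amino compounds end at a limit of the assay, so the change shows no sign of a lower number on either core, but neither the true size of each step nor whether the change carries over equally can be read: the limit of > 100000 nM in this assay, at which 2 of the 4 values shown sit.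

From the compounds shown here alone, it remains open what a methylamino or a hydroxyl group would do on the same aromatic carbon between two ring nitrogen atoms. Also open, going by these compounds, is where compound 2 and compound 4 would fall on a scale reaching past this limit.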